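Swapping the Substituted Pyrazole for a Thiazole

The source may report more compounds than this note shows. Statements on the series, on what has been measured and on what is new or still open speak of the compounds shown alone.

Compound 3 `Cc1ccc(CNC(=O)c2cccc(C(C)Oc3cccnc3Nc3cnn(CC(C)(C)O)c3)c2)cc1` stands at the low end of the numbers gathered so far in a functional assay on NCI-H3122 cells (Homo sapiens) for antiproliferative activity, read by MTT assay, with a stated time of 48 h (a lower number here means a stronger inhibitor, a higher number a weaker inhibitor), where compound 3 gives 9100 nM. Compound 1 `COc1cccc(CNC(=O)c2cccc(C(C)Oc3cccnc3Nc3cnn(C)c3)c2)c1` gives 49400 nM. Compound 2 `Cc1ccc(CNC(=O)c2cccc(C(C)Oc3cccnc3Nc3ncccn3)c2)cc1` reaches only a limit of the assay, > 100000 nM. For the measured compounds named here, the one step measured on this nitrogen is an at least 10-fold lower number from compound 2 to compound 3 (1.04 log units; beyond the scatter). Compound 4 `Cc1ccc(CNC(=O)c2cccc(C(C)Oc3cccnc3Nc3nccs3)c2)cc1` carries 1,3-thiazol-2-yl in place of 1-(2-hydroxy-2-methylpropyl)-1H-pyrazol-4-yl on a nitrogen on an aromatic ring. The thiazol-2-yl that enters is a small unsubstituted azole, closer in kind to the pyrimidin-2-yl of compound 2 than to the substituted pyrazole of compound 3, so a sizeable move toward weaker inhibition is expected, possibly as far as the limit of > 100000 nM in this assay, at which 1 of the 3 values shown sits. Compound 4 is therefore estimated at 60000 nM, with a range from 15000 nM to 200000 nM. That corresponds to an expected step of a 6.6-fold higher number from compound 3 to compound 4 (0.82 log units; beyond the scatter).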

Compound 4, half-maximal inhibitory concentration: 15300 nM
Beside the measured number, compound 4's estimate is 3.9-fold (0.59 log units) above it; the range from low to high includes it.
By their numbers in this assay, from the lowest: compounds 3 and 4 (each within the scatter of the next); then compound 1. At a limit, above all of these: compound 2.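

In this assay, the 2-hydroxy-2-methylpropyl-substituted pyrazole on this nitrogen turns out not to be required, since replacing it with the much smaller 1,3-thiazol-2-yl gives a 1.7-fold higher number from compound 3 to compound 4 (0.23 log units; within the scatter). A small unsubstituted ring as such therefore does not account for the poor result of pyrimidin-2-yl, as the change of ring gives an at least 6.5-fold lower number from compound 2 to compound 4 (0.81 log units; beyond the scatter). The value of compound 2 is a limit of the assay: the limit of > 100000 nM in this assay, at which 1 of the 4 values shown sits.

The compounds shown leave open whether a thiazole carrying an aminomethyl group or a carboxylic acid would shift the number at this nitrogen. From the compounds shown here alone, how a plain phenyl ring would read here also remains open.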